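Methoxy for trifluoromethyl on two related cores

The source may hold more compounds than are shown below. What is called first, only, known or untested is meant among the compounds shown, and "the series" means these compounds.

Compound 1 `O=C1C=COC(/C=C/c2ccc(C(F)(F)F)cc2)C1` and compound 2 `COc1ccc(/C=C/C2CC(=O)C=CO2)cc1` share one core, while compound 3 `O=C1C=CCC(/C=C/c2ccc(C(F)(F)F)cc2)N1` and compound 4 `COc1ccc(/C=C/C2CC=CC(=O)N2)cc1` share another. How the core of compound 3 differs from the core of compound 1 is not broken down here. In an ADME assay on HaCaT cells (Homo sapiens) for inhibition, read by sulforhodamine B assay, with a stated time of 48 h (a higher number here means a weaker inhibitor of growth, a lower number a stronger inhibitor of growth), compound 1 gives 123 uM, compound 2 gives 145 uM and compound 3 gives 174 uM. All three numbers lie within the usual scatter of one another, so no order among them is read.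

The change from compound 1 to compound 2 is methoxy in place of trifluoromethyl on an aromatic carbon. It made a step of a 1.2-fold higher number from compound 1 to compound 2 (0.07 log units; within the scatter), which is within the scatter. The same change, (methoxy in place of trifluoromethyl on an aromatic carbon), is made from compound 3 to compound 4, at a place described in the same words on both cores, so it is the same change.

For compound 4 in this assay the expected step is a 1.1-fold higher number from compound 3 to compound 4 (0.05 log units; within the scatter). Going by the values given here, this expectation rests on the one measured instance of the change, which gave a 1.2-fold higher number from compound 1 to compound 2 (0.07 log units; within the scatter). Compound 4 is estimated at 195 uM, with a likely range from 110 uM to 350 uM. One precedent on another core is a thin basis, so the range is kept wide.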

Compound 4, concentration for growth inhibition (reported as GI): > 1090 uM
Compound 4: no number, only a limit (the forecaster's own chance of this, stated with the estimate: 10%); at least 5.5-fold (0.74 log units) between middle value and limit.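

In this assay compound 4 gives > 1090 uM, which is a limit of the assay and not a number. Methoxy in place of trifluoromethyl on an aromatic carbon gives an at least 6.2-fold higher number from compound 3 to compound 4 (0.79 log units; beyond the scatter), so the step seen on the core of compound 1 does not carry over in size to the core of compound 3: the same change on two cores in this assay, a 1.2-fold higher number (0.07 log units; within the scatter) from compound 1 to compound 2 and an at least 6.2-fold higher number (0.79 log units; beyond the scatter) from compound 3 to compound 4, at least 5.3-fold (0.72 log units) apart, beyond the scatter of two such steps With one pair on each core, this shows only that the result of the change differed between these two cores; it does not show why they differ, how large the step from compound 3 to compound 4 really is, or how the change would behave on any further core.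

The compounds shown leave open whether the gap between the two steps is tied to methoxy alone or would also appear with another group on the same aromatic carbon, such as a chlorine, a nitrile or an amine. Going by these compounds alone, they also leave open which part of the difference between the two cores matters, since no pair isolates a single change within the core.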